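Working notes: ethoxy in place of fluoro

This account rests on a few compounds, and the source may have more. Where it says the series, first, only, none or still open, it means among the compounds named here.

Measured in a functional assay on MOLT-4 cells (Homo sapiens) for antiproliferative activity, with a stated time of 48 h; a higher number here means a weaker inhibitor, a lower number a stronger inhibitor
- compound 1 `C=C(Br)C(=O)Nc1ccc(/C=C/C(=O)c2ccc(F)cc2)cc1` gives 660 nM
- compound 2 `Nc1ccc(/C=C/C(=O)c2ccc(F)cc2)cc1` gives 12000 nM

Within the data shown here, compound 2 stands at 12000 nM as the higher of the two numbers so far. Compound 3 `CCOc1ccc(C(=O)/C=C/c2ccc(N)cc2)cc1` differs from compound 2 by ethoxy in place of fluoro on an aromatic carbon with ethoxy in place of fluoro on an aromatic carbon, para to a large group. Among the measured compounds shown here, the one measured step of an 18-fold higher number from compound 1 to compound 2 (1.26 log units; beyond the scatter) is large but sits on the nitrogen and not on this carbon, so it gives no size for this change. No step beyond the scatter is therefore expected in this assay and no direction is favoured. The expected step is a 1.3-fold lower number from compound 2 to compound 3 (0.12 log units; within the scatter) on this estimate. Compound 3 is estimated at 9000 nM with an expected range from 3000 nM to 27000 nM in this reading.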

Compound 3, half-maximal inhibitory concentration: 11000 nM
Compound 3: middle estimate off by 1.2-fold (0.09 log units), on the low side; measured number inside the range.
By their numbers in this assay, from the lowest: compound 1; then compounds 3 and 2 (each within the scatter of the next).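

In this assay, among these compounds, ethoxy in place of fluoro gives a 1.1-fold lower number from compound 2 to compound 3 (0.04 log units; within the scatter), the first reading at this aromatic carbon, para to a large group. The carbon thus takes ethoxy, 3 heavy atoms against 1 for fluoro, with no change beyond the scatter, at least while the nitrogen carries no acyl group. No available data bear on the reason for this result.

From the compounds shown here alone, whether ethoxy gives the same result with the (1-bromoethenyl)carbonyl on the nitrogen, as in compound 1, remains open. Also open, going by these compounds, is how an amine, a carboxylic acid or a longer alkoxy chain would read on this carbon.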